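Removing the chloro from the pyridine ring of compound 3

The source may hold more compounds than are shown below. What is called first, only, known or untested is meant among the compounds shown, and "the series" means these compounds.

Of the compounds shown here, three have been measured in an in vitro assay on SH-EP1 cells for displacement of a labelled ligand from Neuronal acetylcholine receptor; alpha4/beta2 (Homo sapiens); a lower number here means a stronger inhibitor, a higher number a weaker inhibitor. Compound 1 `Clc1ccncc1C1=CC2CNCC(C1)C2` gives 3 nM, compound 2 `C1=C(c2cccnc2)C[C@@H]2CNC[C@H]1C2` gives 0.1 nM, and compound 3 `Clc1cncc(C2=CC3CNCC(C2)C3)c1` gives 0.4 nM. Compound 3 thus stands second highest of the three numbers: its nearest neighbour is compound 2, which lies below it beyond the usual scatter, and compound 1 lies above it, also beyond the scatter.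

The next step goes from compound 3 to compound 4 `C1=C(c2cccnc2)CC2CNCC1C2`, a change of hydrogen in place of chloro on an aromatic carbon. Among the measured compounds shown here, no step between measured compounds of the same kind is known here, so the expected size must be read from the compounds themselves. Compound 4 has the same atoms and bonds as compound 2; compound 2 is drawn with its stereo-centres assigned, compound 4 is drawn without them. Given that compound 2 gives 0.1 nM, compound 4 is expected to land near that number, with an expected step from compound 3 to compound 4 of a 2.7-fold lower number from compound 3 to compound 4 (0.43 log units; beyond the scatter), downward and beyond the scatter. The estimate for compound 4 in this assay is 0.15 nM, within a range of 0.05 nM to 0.5 nM.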

Compound 4, inhibition constant: 0.2 nM
For compound 4 the middle estimate is 1.3-fold (0.12 log units) below the measured one; low and high end bracket the measured number.
By their numbers in this assay, from the lowest: compounds 2, 4 and 3 (each within the scatter of the next, the first and the last beyond it); then compound 1.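

In this assay, hydrogen in place of chloro on this aromatic carbon, two atoms from the ring nitrogen, gives a 2.0-fold lower number from compound 3 to compound 4 (0.30 log units; within the scatter), so at this place the two substituents are not told apart. The same exchange starting from compound 1, whose chloro sits on a different ring carbon, gives a 15-fold lower number from compound 1 to compound 4 (1.18 log units; beyond the scatter), so across these two compounds the size of the exchange depends on which carbon carries the chloro. Compound 4 also stays close to its stereo-defined counterpart, with a 2.0-fold higher number from compound 2 to compound 4 (0.30 log units; within the scatter), and the only structural difference behind that step is this: the fact that one of compounds 2 and 4 is drawn with a defined configuration and the other without, at the place where they differ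

On these data alone, whether a larger change at the carbon of compound 3, such as a methoxy group, an amine or a nitrile, would separate from hydrogen and chloro remains open. Among the compounds shown here, also open is how the single stereo-defined form of compound 2 would compare with its mirror-image form, and whether a chloro on the stereo-defined core would follow the same pattern.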